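This account rests on a few compounds, and the source may have more. Where it says the series, first, only, none or still open, it means among the compounds named here.

Measured so far:
Compound 1, `Nc1nc(C2CCCO2)nc2sc(Cc3ccccc3)cc12`, gives 2950 nM in a functional assay on CHO-K1 cells for antagonist activity at adenosine receptor A1 (Homo sapiens), read by a beta-galactosidase reporter and cAMP accumulation, with stated times of 15 min and 6 h; on this read-out higher numbers stand for weaker inhibition and lower numbers for stronger inhibition.
Compound 2, `Nc1nc(-c2cccc(C(F)(F)F)c2)nc2sc(Cc3ccccc3)cc12`, gives > 1000 nM in this assay, which is a limit of the assay and not a number.

Compound 1 holds the only number shown in this assay; the one further value is a limit. For compound 2 that limit is the limit of > 1000 nM in this assay, at which 1 of the 2 values shown sits. Within the data shown here, no step between measured compounds that differ in one place is available, so no measured change of this kind can guide the next compound. Compound 3, `Nc1nc(-c2cccc(Cl)n2)nc2sc(Cc3ccccc3)cc12`, differs from compound 1 in one place: 6-chloropyridin-2-yl in place of oxolan-2-yl on an aromatic carbon. With nothing measured on such a change, the expectation rests only on compound 1 at 2950 nM; the step is expected to be modest and toward stronger inhibition, about a 2.0-fold lower number from compound 1 to compound 3 (0.29 log units; within the scatter), at the edge of the scatter. Compound 3 is therefore estimated at 1500 nM, with a range from 300 nM to 8000 nM.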

Compound 3, inhibition constant: > 1000 nM
Compound 3: a limit, no number; the forecaster's own chance of this, stated with the estimate: 30%; the middle value lies beyond the limit too.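

Among these compounds, compound 3 gives > 1000 nM in this assay, which is a limit of the assay and not a number, so no step from compound 1 to compound 3 can be read. The compounds shown leave open whether compound 2 or compound 3 inhibits more strongly or more weakly than compound 1.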